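The compounds below may be only part of what the source reports. "The series", "measured", "known", "first", "only" and "open" are said of these compounds alone.

Two urea compounds built on a shared core have been measured in a functional assay on HepG2 cells (Homo sapiens) for antiproliferative activity, read by MTT assay, with a stated time of 48 h; a higher number here means a weaker inhibitor, a lower number a stronger inhibitor. Compound 1 `Cc1ccc(NC(=O)Nc2cccc(CNc3nccnc3Cl)c2)c(C)c1` gives 9290 nM in this assay. Compound 2 `O=C(Nc1ccc(C(F)(F)F)cc1)Nc1cccc(CNc2nccnc2Cl)c1`, a close relative, gives 5050 nM in this assay. Compound 1 stands at the high end of the two numbers, but compound 2 lies within the scatter of it, so no ranking of the two is warranted; both simply sit in the same micromolar region.

Compound 3 `O=C(Nc1cccc(CNc2nccnc2Cl)c1)Nc1ccccc1Cl` is the unmeasured compound that follows from compound 1 by a single change: 2-chlorophenyl in place of 2,4-dimethylphenyl on an amide-type nitrogen. For the measured compounds named here, no measured pair shows what such a change does, so the expectation can rest only on the two values at hand, which lie close together. The expected step of a 1.3-fold lower number from compound 1 to compound 3 (0.12 log units; within the scatter) in this assay is therefore no larger than the scatter of repeated measurements, with no clear direction. On that basis compound 3 is estimated to give 7000 nM, within a range from 2500 nM to 20000 nM.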

Compound 3, half-maximal inhibitory concentration: 8560 nM
Beside the measured number, compound 3's estimate is 1.2-fold (0.09 log units) below it; the range from low to high includes it.
By their numbers in this assay, from the lowest: compounds 2, 3 and 1 (each within the scatter of the next).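

For the compounds shown here, replacing 2,4-dimethylphenyl with 2-chlorophenyl on an amide-type nitrogen gives a 1.1-fold lower number from compound 1 to compound 3 (0.04 log units; within the scatter) in this assay, and this is the first measured pair that differs in only one place. The position therefore tolerates this exchange of one carbon-only aromatic ring carrying different groups for another without any change that can be told from the scatter of repeated measurements, so, for this one pair, the swap leaves the antiproliferative reading in the same micromolar region. Going by these compounds alone, nothing available explains this result, and the single step shows only this one exchange, not how the position responds to substitution in general.

The compounds shown all carry an aromatic ring with a small group or groups at this nitrogen, so it remains open whether a clearly different group there, such as a carboxylic acid or a dimethylamino group on that ring, would move the number beyond the scatter. Going by these compounds, it also remains open how the reading would respond to a change elsewhere on the shared core, for instance an amine in place of its chlorine.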